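A few compounds are considered here, and "the series" means these few. Any claim that something is new, unique, unknown or untested is made for them only; others in the source may bear on it.

Measured compounds:
compound 1 `CNC(=O)C#Cc1ccc(NC(=O)Nc2ccc(Cl)c(C(F)(F)F)c2)cc1` — > 50000 nM
compound 2 `C/C(=C\c1ccc(NC(=O)Nc2ccc(Cl)c(C(F)(F)F)c2)cc1)C(=O)N1CC(C)OC(C)C1` — > 50000 nM

In a functional assay on A-375 cells (Homo sapiens) for inhibition, read by MTT assay, with a stated time of 120 h (on this read-out higher numbers stand for weaker inhibition and lower numbers for stronger inhibition), compound 1 gives > 50000 nM, which is a limit of the assay rather than a number. Compound 2 likewise reaches only > 50000 nM, again a limit. Compound 1 thus stands where every shown value stands: the limit of > 50000 nM in this assay, at which 2 of the 2 values shown sit. Going by the values given here, no step between two measured compounds is available to calibrate the change. Compound 3 `O=C(CCc1ccc(NC(=O)Nc2ccc(Cl)c(C(F)(F)F)c2)cc1)NC1CCC1` differs from compound 1 by 2-(cyclobutylcarbamoyl)ethyl in place of 2-(methylcarbamoyl)ethynyl on an aromatic carbon. Both compounds in hand sit at the limit, so the shown numbers give no sign that inhibition becomes measurable with this change. The step from compound 1 to compound 3 is expected to be none beyond the scatter, a number no higher from compound 1 to compound 3 (the limit leaves the size open). Compound 3 is accordingly estimated at 50000 nM, with a range from 15000 nM to 150000 nM, most likely reported as a limit once more.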

Compound 3, half-maximal inhibitory concentration: > 50000 nM
Compound 3 was reported as a limit; the forecaster's own chance of this, stated with the estimate: 75%; the middle value lies on the limit itself.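

In this assay compound 3 gives > 50000 nM as a limit of the assay, not a number. Going by these compounds alone, no step between compound 1 and compound 3 can be read from two limits. The compounds shown leave open which change to the shared core, if any, would bring a measurable value.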